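This account rests on a few compounds, and the source may have more. Where it says the series, first, only, none or still open, it means among the compounds named here.

Working notes on the series. Three compounds have numbers in a functional assay on HeLa cells (Homo sapiens) for inhibition, read by cell counting, with a stated time of 4 days; a higher number here means a weaker inhibitor, a lower number a stronger inhibitor. Compound 3 `C=C(Br)C(=O)Nc1cccc(-c2cn3nc(-c4ccc(C)cc4)sc3n2)c1` gives 2000 nM and stands at the low end of the three, with compound 1 `C=C(Br)C(=O)Nc1cccc(-c2cn3nc(-c4ccc(CC)cc4)sc3n2)c1` nearest at 3200 nM and compound 2 `COc1ccc(Cc2nn3cc(-c4cccc(N)c4)nc3s2)cc1` furthest at 191000 nM. Among the compounds with values here, the only single-place step among the measured compounds is a 1.6-fold lower number from compound 1 to compound 3 (0.20 log units; within the scatter), which shows that a small change at the distal aromatic ring leaves this assay essentially untouched.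

Compound 4 `C=C(Br)C(=O)Nc1cccc(-c2cn3nc(Cc4ccc(OC)cc4)sc3n2)c1` is not yet measured. Relative to compound 3 the change is 4-methoxybenzyl in place of 4-methylphenyl on an aromatic carbon. Within the data shown here, no measured step bears directly on this change; the one step known is far smaller in kind. Compound 2 carries the same 4-methoxybenzyl group and gives a much higher number, but it is not a single-step neighbour of compound 4, so its value can only be a warning, not a guide. Replacing the 4-methylphenyl by the larger, more flexible 4-methoxybenzyl is expected to weaken inhibition, with the step from compound 3 to compound 4 estimated as a 4.0-fold higher number from compound 3 to compound 4 (0.60 log units; beyond the scatter). Compound 4 is expected to give 8000 nM, within the range 2000 nM to 40000 nM.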

Compound 4, half-maximal inhibitory concentration: 2300 nM
The estimate for compound 4 lay 3.5-fold (0.54 log units) above the measured number; measured number inside the range.
By their numbers in this assay, from the lowest: compounds 3, 4 and 1 (each within the scatter of the next); then compound 2.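

At the aromatic carbon next to the ring nitrogen and next to the ring sulfur, this assay does not separate 4-methoxybenzyl from 4-methylphenyl, with a 1.2-fold higher number from compound 3 to compound 4 (0.06 log units; within the scatter), or from 4-ethylphenyl, with a 1.4-fold lower number from compound 1 to compound 4 (0.14 log units; within the scatter); these three groups therefore read alike here, although 4-methoxybenzyl is the larger by heavy atoms and adds a hydrogen-bond acceptor. The large step lies at the other place, an 83-fold lower number from compound 2 to compound 4 (1.92 log units; beyond the scatter), where (1-bromoethenyl)carbonyl stands in place of hydrogen on the nitrogen, so the high number of compound 2 says nothing against 4-methoxybenzyl. No measurement shown here accounts for either result. Going by these compounds, whether this insensitivity extends to a carboxylic acid or an amine on the distal ring remains open. Also open, on these data alone, is whether an acetyl group on that nitrogen would match the (1-bromoethenyl)carbonyl.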